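The compounds below may be only part of what the source reports. "The series", "measured", "known", "first", "only" and "open" are said of these compounds alone.

Compound 1 `CC(=O)N1CCC(C(=O)N(CCCN2CCC(CNc3cc(C)ccn3)CC2)c2ccc(C)c(Cl)c2)CC1` is one of two compounds examined in an ADME assay (Homo sapiens) for cytotoxicity; a lower number here means that less compound is tolerated, a higher number that more compound is tolerated. In this assay, among the measured compounds shown here, compound 1 gives 17900 nM, the only outright number obtained. Compound 2 `CC(=O)N1CCC(C(=O)N(CCCN2CCN(Cc3ccc(C#N)cc3)CC2)c2ccc(C)c(Cl)c2)CC1` gives in this assay a limit of the assay, > 100000 nM. For the measured compounds named here, compound 1 thus stands as the sole numeric value, the other result sitting at the limit of > 100000 nM in this assay, at which 1 of the 2 values shown sits. Compound 3 `CCN(Cc1ccccc1)C(=O)C1CCN(CCCN(C(=O)C2CCN(C(C)=O)CC2)c2ccc(C)c(Cl)c2)CC1` differs from compound 1 in one place: benzyl(ethyl)carbamoyl in place of ((4-methylpyridin-2-yl)amino)methyl on a saturated ring carbon. Going by the values given here, no step between measured compounds is available to calibrate this change. The step from compound 1 to compound 3 is expected to be a 1.7-fold higher number from compound 1 to compound 3 (0.22 log units; within the scatter), a modest move toward greater tolerance that need not exceed the scatter. Compound 3 is accordingly expected to give about 30000 nM in this assay, within a range from 10000 nM to 100000 nM, with a fair chance that only a limit is reported.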

Compound 3, half-maximal cytotoxic concentration: 83.9 nM
The estimate for compound 3 lay 360-fold (2.55 log units) above the measured number; the whole stated range lies above it.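

In this assay, the saturated ring carbon three ring bonds from the ring nitrogen proves highly sensitive: benzyl(ethyl)carbamoyl in place of ((4-methylpyridin-2-yl)amino)methyl gives a 210-fold lower number from compound 1 to compound 3 (2.33 log units; beyond the scatter). Among the compounds shown here, the earlier compounds offered no step in one place, so this is the first sign that a change at this position can move tolerance so far. The result of compound 2 remains a limit of the assay and is not a number: the limit of > 100000 nM in this assay, at which 1 of the 3 values shown sits.

The exchange alters several things at once, replacing the pyridine ring with an aromatic ring of carbon only, losing the hydrogen-bond donor and introducing a carbonyl, and the compounds shown do not tell which of these carries the step. An ethylcarbamoyl group without the benzyl, or a benzylaminomethyl group, at the same ring carbon would begin to separate them.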